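Alkyl chain lengthening on a shared nucleoside core

This account rests on a few compounds, and the source may have more. Where it says the series, first, only, none or still open, it means among the compounds named here.

Compound 1: `CCCCCCc1cn([C@H]2C[C@@H]3OP(=O)(O)OC[C@H]3O2)c(=O)[nH]c1=O`, > 500 ug/mL
Compound 2: `CCCCc1cn([C@H]2C[C@H](O)[C@@H](CO)O2)c(=O)[nH]c1=O`, > 500 ug/mL
Compound 3: `CCCCCc1cn([C@H]2C[C@@H]3OP(=O)(O)OC[C@H]3O2)c(=O)[nH]c1=O`, > 500 ug/mL

Of the compounds shown here, three have been tested in a functional assay on Raji cells (Homo sapiens); on this read-out higher numbers stand for weaker inhibition and lower numbers for stronger inhibition. Compound 3 has the structure `CCCCCc1cn([C@H]2C[C@@H]3OP(=O)(O)OC[C@H]3O2)c(=O)[nH]c1=O` and in this assay gives > 500 ug/mL, which is a limit of the assay rather than a number. Compound 1, with the structure `CCCCCCc1cn([C@H]2C[C@@H]3OP(=O)(O)OC[C@H]3O2)c(=O)[nH]c1=O`, also gives > 500 ug/mL in this assay, again a limit. Compound 2, with the structure `CCCCc1cn([C@H]2C[C@H](O)[C@@H](CO)O2)c(=O)[nH]c1=O`, gives > 500 ug/mL in this assay, once more a limit. The step from compound 3 to compound 1 is methyl in place of hydrogen on a saturated chain carbon, five bonds along the chain from an aromatic carbon, and its size is a step that the two limits leave unreadable from compound 3 to compound 1, because of the limit of > 500 ug/mL in this assay, at which 3 of the 3 values shown sit.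

Compound 4, with the structure `CCCCCc1cn([C@H]2C[C@H](O)[C@@H](CO)O2)c(=O)[nH]c1=O`, has not yet been measured. Compared with compound 2 it carries methyl in place of hydrogen on a saturated chain carbon, four bonds along the chain from an aromatic carbon. The change from compound 3 to compound 1 is the same kind of change, but the place differs: there the methyl enters five bonds along the chain from an aromatic carbon, here four bonds along the chain. The difference between the core of compound 2 and the core of compound 3 is not broken down here.

For compound 4 the step from compound 2 is expected to be a step that the limit leaves unreadable from compound 2 to compound 4, resting on compound 2 giving > 500 ug/mL and on the step from compound 3 to compound 1 being a step that the two limits leave unreadable from compound 3 to compound 1. Compound 4 is therefore estimated at 800 ug/mL in this assay, between 300 ug/mL and 3000 ug/mL, most likely reported as a limit.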

Compound 4, concentration for 50% inhibition: 334 ug/mL
For compound 4 the middle estimate is 2.4-fold (0.38 log units) above the measured one, within the range that was stated.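

On the core of compound 2, methyl in place of hydrogen on a saturated chain carbon, four bonds along the chain from an aromatic carbon, gives an at least 1.4-fold lower number from compound 2 to compound 4 (0.17 log units; that floor lies within the scatter) in this assay, so this pair shows no change beyond the usual scatter, although the true step may be larger than that floor. The same kind of change on the core of compound 3, where the methyl enters five bonds along the chain, cannot be read, because both of its end points sit at a limit rather than at a number: the limit of > 500 ug/mL in this assay, at which 3 of the 4 values shown sit. The series therefore neither shows that the change carries from one core to the other nor shows that it fails to carry, and the comparison is further blurred by the different place of the methyl on the two chains.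

Going by these compounds, what remains open is whether the small gain hinted at on the core of compound 2 would continue with a longer chain, such as an octyl chain, on that core. On these data alone, it is also open how this assay would respond to an amine or a carboxylic acid on the chain of either core.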